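A few compounds are considered here, and "the series" means these few. Any claim that something is new, unique, unknown or untested is made for them only; others in the source may bear on it.

Compound 3 `CO[C@@H]1[C@H](N(C)c2ncc(-c3c[nH]c4ccccc34)s2)C[C@H]2O[C@]1(C)n1c3ccccc3c3c4c(c5c6cc(Br)ccc6n2c5c31)C(=O)NC4` is tested in a functional assay on HL-60 cells (Homo sapiens) for antiproliferative activity, read by CellTiter-Glo, with a stated time of 72 h; on this read-out higher numbers stand for weaker inhibition and lower numbers for stronger inhibition. Compound 3 gives only a limit of the assay there, > 10000 nM. Two related compounds stand beside it. Compound 1 `CO[C@@H]1[C@H](N(C)c2ncc(-c3c[nH]c4ccc(F)cc34)s2)C[C@H]2O[C@]1(C)n1c3ccccc3c3c4c(c5c6ccccc6n2c5c31)C(=O)NC4` also gives only a limit, > 10000 nM. Compound 2 `CO[C@@H]1[C@H](N(C)c2ncc(-c3c[nH]c4ccc(F)cc34)s2)C[C@H]2O[C@]1(C)n1c3ccccc3c3c4c(c5c6cc(Cl)ccc6n2c5c31)C(=O)NC4` likewise gives only a limit, > 10000 nM. For the measured compounds named here, the step that the two limits leave unreadable from compound 1 to compound 2 therefore cannot be sized, and the limit of > 10000 nM in this assay, at which 3 of the 3 values shown sit, means no measured step carries a readable size. Compound 4 `CO[C@@H]1[C@H](N(C)c2ncc(-c3c[nH]c4ccc(F)cc34)s2)C[C@H]2O[C@]1(C)n1c3ccccc3c3c4c(c5c6cc(Br)ccc6n2c5c31)C(=O)NC4` differs from compound 3 by fluoro in place of hydrogen on an aromatic carbon, a change that compound 1 and compound 2 already carry. With every value sitting at the limit, no movement beyond the scatter is expected, and compound 4 is estimated at 20000 nM, between 10000 nM and 50000 nM, an expected step that the limit leaves unreadable from compound 3 to compound 4.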

Compound 4, half-maximal inhibitory concentration: > 10000 nM
Compound 4: no number, only a limit; the forecaster's own chance of this, stated with the estimate: 85%; the middle value is on the limit's open side.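

Compound 4 gives only a limit, so no step linking it to compound 1, compound 2 or compound 3 can be read: the limit of > 10000 nM in this assay, at which 4 of the 4 values shown sit.

The compounds shown leave open whether swapping hydrogen, fluoro, chloro or bromo changes activity at all.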